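Moving a fluorine around the benzamide ring

The source may report more compounds than this note shows. Statements on the series, on what has been measured and on what is new or still open speak of the compounds shown alone.

Compound 2 `COc1ccccc1C(=O)NCc1ccc(CNS(=O)(=O)c2ccc(C)cc2)cc1` carries a 2-methoxyphenyl group on the carbonyl carbon of the shared core; in an assay on MDA-MB-231 cells for binding affinity to C-X-C chemokine receptor type 4 (Homo sapiens), read by immunofluorescence and microscopy, with stated times of 10 min and 30 min (a higher number here means that more compound is needed for the effect, a lower number that less compound is needed), compound 2 gives 100 nM, the highest of the two numbers measured. Among the compounds with values here, its only neighbour is compound 1 `Cc1ccc(S(=O)(=O)NCc2ccc(CNC(=O)c3ccc(F)cc3)cc2)cc1`, which in this assay gives 1 nM. Within the data shown here, the one step measured, a 100-fold higher number from compound 1 to compound 2 (2.00 log units; beyond the scatter), is therefore large and runs towards the higher number when 2-methoxyphenyl replaces 4-fluorophenyl.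

Compound 3 `Cc1ccc(S(=O)(=O)NCc2ccc(CNC(=O)c3cccc(F)c3)cc2)cc1` differs from compound 2 in one place: 3-fluorophenyl in place of 2-methoxyphenyl on a carbonyl carbon. This change removes the group that brought the high number in compound 2 and returns a fluorophenyl group of the kind found in compound 1, though the fluorine now stands at the 3-position of the ring. Because compound 1 gives 1 nM with its fluorophenyl amide, compound 3 is expected to move back towards that value, with an expected step of a 25-fold lower number from compound 2 to compound 3 (1.40 log units; beyond the scatter). How much the shift of the fluorine costs is not known from these two compounds, so the range is set wide. Compound 3 is estimated at 4 nM, between 1 nM and 30 nM.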

Compound 3, effective concentration (reported as EC, without a stated level of effect): 1 nM
For compound 3 the middle estimate is 4.0-fold (0.60 log units) above the measured one; the range from low to high includes it.
By their numbers in this assay, from the lowest: compounds 1 and 3 (each within the scatter of the next); then compound 2.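

With compound 3 alongside compound 1, two fluorophenyl groups on the carbonyl carbon can now be compared directly: in this assay, 3-fluorophenyl in place of 4-fluorophenyl gives no change at the digits printed from compound 1 to compound 3 (within the scatter), so the two groups cannot be told apart here. The return from 2-methoxyphenyl to a fluorophenyl group, a 100-fold lower number from compound 2 to compound 3 (2.00 log units; beyond the scatter), matches the size of the earlier step from compound 1 to compound 2 in the opposite direction. Among the three groups shown, the high number therefore goes with 2-methoxyphenyl alone and not with one particular placement of the fluorine, although no measurement shown gives a reason for this difference. The compounds shown leave open whether the large step follows the methoxy group itself or its place on the ring, as 2-methoxyphenyl is the only methoxy-bearing group among them. They also leave open how a plain phenyl group, or a phenyl group carrying an amine or a carboxylic acid, would behave on the same carbonyl carbon, and whether the sulfonamide side of the shared core would tolerate change.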